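The compounds below may be only part of what the source reports. "The series", "measured", "known", "first", "only" and "open" are said of these compounds alone.

Compound 2 `O=C(O)C[C@@H](NC(=O)[C@@H]1CCN1S(=O)(=O)c1cc(Cl)cc(Cl)c1)c1ccc(F)cc1` is examined in an assay on RPMI-8866 cells for inhibition of integrin alpha-4/beta-1 (Homo sapiens) (on this read-out higher numbers stand for weaker inhibition and lower numbers for stronger inhibition), where compound 2 gives 3.2 nM. Among the three measured compounds this is the second highest number. Its nearest neighbour is compound 3 `O=C(O)C[C@@H](NC(=O)[C@@H]1CCCN1S(=O)(=O)c1cc(Cl)cc(Cl)c1)c1ccc(OC(F)(F)F)cc1`, for which compound 3 gives 2.6 nM in this assay, a gap within the usual scatter. Furthest away is compound 1 `O=C(O)CCNC(=O)[C@@H]1CCCN1S(=O)(=O)c1cc(Cl)cc(Cl)c1`, which in this assay gives 1510 nM.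

Within the data shown here, the only single-point step measured is that from compound 1 to compound 3, where the number moves a 580-fold lower number from compound 1 to compound 3 (2.76 log units; beyond the scatter) on introduction of the 4-(trifluoromethoxy)phenyl group. That step shows the weight of having an aromatic group at this carbon at all; it says nothing direct about exchanging one aromatic group for another.

Compound 4 `COc1ccc([C@@H](CC(=O)O)NC(=O)[C@@H]2CCN2S(=O)(=O)c2cc(Cl)cc(Cl)c2)cn1` differs from compound 2 by 6-methoxypyridin-3-yl in place of 4-fluorophenyl on a saturated chain carbon bound to an amide-type nitrogen and a saturated chain carbon. The change keeps an aromatic ring in place, which compound 2 and compound 3 show to be tolerated with two different substitution patterns at values within the scatter of each other. Among the measured compounds shown here, no measured step bears on a ring nitrogen or a methoxy group here. The step from compound 2 to compound 4 is therefore expected to be a 1.6-fold higher number from compound 2 to compound 4 (0.19 log units; within the scatter), not beyond the scatter. In this assay compound 4 is expected to give about 5 nM, with a range from 1.5 nM to 20 nM.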

Compound 4, half-maximal inhibitory concentration: 3 nM
Estimate against measurement, compound 4: 1.7-fold (0.22 log units) above; the measured number falls inside the stated range.
By their numbers in this assay, from the lowest: compounds 3, 4 and 2 (each within the scatter of the next); then compound 1.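

Read in this assay, the exchange of 4-fluorophenyl for 6-methoxypyridin-3-yl on the saturated chain carbon gives a 1.1-fold lower number from compound 2 to compound 4 (0.03 log units; within the scatter), and this is the first direct reading of one aromatic group replaced by another at this position, since the earlier step showed only what introducing such a group does. Among these compounds, the result therefore extends what is tolerated at this carbon to a six-membered aromatic ring with a hetero atom that also carries a methoxy group, a kind of substituent absent from the earlier compounds, while the number stays within the scatter. Nothing is available on why this exchange leaves the number within the scatter, and no separate measurement bears on the result.

Since the ring nitrogen and the methoxy group enter together, the compounds shown do not separate them: neither a plain pyridin-3-yl nor a 4-methoxyphenyl group is among them to show what each contributes alone. Also open, on these data alone, is whether this position accepts an amine or a carboxylic acid on the aromatic ring, or a longer alkoxy chain in place of the methoxy group, and whether the exchange would read the same on the core of compound 3.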